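The compounds below may be only part of what the source reports. "The series", "measured", "known", "first", "only" and "open" are said of these compounds alone.

Working notes on the series. The shared core of compound 1 `CC(C)(C)OC(=O)CCCN1CCc2c(sc(NC(=O)Nc3ccc(Cl)cc3)c2C(N)=O)C1` carries a 3-(tert-butoxycarbonyl)propyl chain on the ring nitrogen. In a functional assay (strain AB) with Danio rerio as the target, read by microscopy, with a stated time of 1 h (a higher number here means that more compound is needed for the effect, a lower number that less compound is needed), compound 1 gives 560 nM. Two further analogues have numbers in this assay. Compound 3 `CC(C)(C)C[N+]1(C)CCc2c(sc(NC(=O)Nc3ccc(Cl)cc3)c2C(N)=O)C1` gives 290 nM; its gap to compound 1 is within the scatter, so no order between the two can be read. Within the data shown here, compound 2 `CCN1CCc2c(sc(NC(=O)Nc3ccc4ccccc4c3)c2C(N)=O)C1` gives 1780 nM, a gap to compound 1 that lies beyond the scatter, but compound 2 differs from compound 1 in more than one place, so what the two values show is only that compound 2 needs more compound. Compound 1 thus stands second highest of the three numbers.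

The next compound, compound 4 `COCCCN1CCc2c(sc(NC(=O)Nc3ccc(Cl)cc3)c2C(N)=O)C1`, is not yet measured. It differs from compound 1 in one place: methoxy in place of tert-butoxycarbonyl on a saturated chain carbon, three bonds along the chain from an amine nitrogen in a ring. Among the measured compounds shown here, no step between two measured compounds isolates this change, so its size is unknown. The three measured numbers sit within a narrow band, and compound 3 shows a different chain on the same nitrogen without a gap beyond the scatter.

Compound 4 is therefore expected to remain close to compound 1, with a step of a 1.1-fold lower number from compound 1 to compound 4 (0.05 log units; within the scatter) not beyond the scatter. For compound 4 the estimate in this assay is 500 nM, within 200 nM to 1400 nM.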

Compound 4, half-maximal effective concentration: 2400 nM
The estimate for compound 4 lay 4.8-fold (0.68 log units) below the measured number; measured number outside the range, above it.
By their numbers in this assay, from the lowest: compounds 3 and 1 (each within the scatter of the next); then compounds 2 and 4 (each within the scatter of the next).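

Among these compounds, replacing tert-butoxycarbonyl with methoxy on a saturated chain carbon, three bonds along the chain from an amine nitrogen in a ring, gives in this assay a 4.3-fold higher number from compound 1 to compound 4 (0.63 log units; beyond the scatter), the first step between measured compounds that differ in one place. The earlier compounds shown here left the size of any change here unknown; this step shows that the group carried on this chain is not indifferent, and that with methoxy in this place more compound is needed for the effect than with tert-butoxycarbonyl. Nothing in hand bears on what lies behind the step.

What the compounds shown leave open is whether the step follows from the ester as such or from the larger group as a whole, since a single exchange cannot separate the two. Among the compounds shown here, a carboxylic acid or a primary amine on the same chain carbon, or a longer chain ending in methoxy, would test this, and the step so far rests on the core of compound 1 alone.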